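The compounds below may be only part of what the source reports. "The series", "measured", "known", "first", "only" and "open" are said of these compounds alone.

Measured compounds:
compound 1 `COc1cc(C(=O)O)ccc1OCCCCOc1ccc(C(=O)CC(C)C)c(O)c1C`: 85.7%
compound 2 `Cc1c(OCCCCOc2ccc(C(=O)O)cc2F)ccc(C(=O)CC(C)C)c1O`: 85%
compound 3 `Cc1c(OCCCCOc2ccc(C(=O)O)cc2)ccc(C(=O)CC(C)C)c1O`: 88%

In an assay on HEK293 cells for positive allosteric modulation of metabotropic glutamate receptor 2 (Rattus norvegicus), read by thallium flux, with a stated time of 2.5 min (on this read-out higher numbers stand for larger maximal responses and lower numbers for smaller maximal responses), compound 3 gives the highest of the three numbers, yet the steps of a number 2.3 percentage points higher from compound 1 to compound 3 (within the scatter) and a number 3 percentage points higher from compound 2 to compound 3 (within the scatter) both sit within the scatter, so the three compounds cannot be told apart on this read-out.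

Compound 4 `Cc1c(OCCCCOc2ccc(C(=O)O)cc2Cl)ccc(C(=O)CC(C)C)c1O` is the next member. It differs from compound 3 by chloro in place of hydrogen on an aromatic carbon, on an aromatic carbon that is ortho to a large group and meta to a carboxy group.

Among the compounds with values here, the steps that bear on this position are the exchanges at that same aromatic carbon: a number 0.7 percentage points lower from compound 1 to compound 2 (within the scatter), a number 2.3 percentage points higher from compound 1 to compound 3 (within the scatter) and a number 3 percentage points higher from compound 2 to compound 3 (within the scatter). Methoxy, fluoro and hydrogen at that carbon all leave the maximal response unchanged within the scatter. Nothing in the series singles out chloro, so no step beyond the scatter is expected for compound 4 in this assay.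

Compound 4 is therefore estimated at 86%, between 76% and 96%, which corresponds to an expected step of a number 2 percentage points lower from compound 3 to compound 4 (within the scatter).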

Compound 4, largest response reached (reported as percent of maximum), in percent of the reference or control that the assay uses: 99.5%
For compound 4 the middle estimate is 13.5 percentage points below the measured one, outside the stated range (above it).
By their numbers in this assay, from the lowest: compounds 2, 1 and 3 (each within the scatter of the next); then compound 4.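

Chloro is the only exchange so far at this aromatic carbon to move the maximal response in this assay beyond the scatter, with a number 11.5 percentage points higher from compound 3 to compound 4 (beyond the scatter), a number 14.5 percentage points higher from compound 2 to compound 4 (beyond the scatter) and a number 13.8 percentage points higher from compound 1 to compound 4 (beyond the scatter). The position, ortho to a large group and meta to a carboxy group, therefore does not accept every substituent alike: hydrogen, fluoro and methoxy cannot be told apart, while chloro stands clear of all three. Nothing available accounts for this difference.

Open, as far as these compounds go, is whether bromo, methyl or trifluoromethyl at this carbon would give a step like that of chloro. Also open, from the compounds shown here alone, is whether chloro keeps its step when an amide or a nitrile stands in place of the carboxy group.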